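Pyridin-4-yl for pyridin-3-yl: compound 1 to compound 4

The source may report more compounds than this note shows. Statements on the series, on what has been measured and on what is new or still open speak of the compounds shown alone.

In a functional assay on HepG2 cells (Homo sapiens) for cytotoxicity, read by MTT assay, with a stated time of 24 h (on this read-out higher numbers stand for weaker inhibition and lower numbers for stronger inhibition), compound 1 `COc1cc(/C=C2\CN(C)C/C(=C\c3cccnc3)C2=O)cc(OC)c1` gives 6910 nM. Compound 2 `COc1cc(/C=C2\CN(C)C/C(=C\c3cccnc3)C2=O)cc(OC)c1OC` gives 9520 nM, and compound 3 `CN1C/C(=C\c2ccc(C#N)cc2)C(=O)/C(=C/c2cccnc2)C1` gives 12700 nM. Compound 1 therefore sits within the scatter of both, and the three values cannot be ranked.

Compound 4 `COc1cc(/C=C2\CN(C)C/C(=C\c3ccncc3)C2=O)cc(OC)c1` is still unmeasured. Its difference from compound 1 is pyridin-4-yl in place of pyridin-3-yl on a double-bonded chain carbon bound to a double-bonded ring carbon.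

For the measured compounds named here, no measured compound carries pyridin-4-yl, so the data hold no direct precedent for this exchange. Going by the values given here, the only measured single-place step is a 1.4-fold higher number from compound 1 to compound 2 (0.14 log units; within the scatter), which stays within the scatter. It is a methoxy in place of hydrogen on an aromatic carbon, a different change, and so bears on this one only indirectly.

No step beyond the scatter is therefore expected in this assay, and the expected step is a 1.2-fold higher number from compound 1 to compound 4 (0.06 log units; within the scatter). The estimated value for compound 4 is 8000 nM. The expected range for compound 4 runs from 3500 nM to 16000 nM.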

Compound 4, half-maximal inhibitory concentration: 9500 nM
Compound 4: middle estimate off by 1.2-fold (0.07 log units), on the low side; low and high end bracket the measured number.
By their numbers in this assay, from the lowest: compounds 1, 4, 2 and 3 (each within the scatter of the next).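

In this assay, pyridin-4-yl in place of pyridin-3-yl on a double-bonded chain carbon bound to a double-bonded ring carbon gives a 1.4-fold higher number from compound 1 to compound 4 (0.14 log units; within the scatter) and so stays within the scatter. This is the first step shown at this position, as the earlier single-place step concerned a methoxy on an aromatic carbon, and on the core of compound 1 this assay does not separate the two pyridinyl groups. No measurement of any property accompanies this result.

Still open, from the compounds shown here alone, is whether pyridin-2-yl or a plain phenyl at this place would also stay within the scatter. Going by these compounds, it is equally open whether pyridin-4-yl would give a similar step alongside the methoxy groups of compound 2 or the nitrile of compound 3.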